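A few compounds are considered here, and "the series" means these few. Any claim that something is new, unique, unknown or untested is made for them only; others in the source may bear on it.

Of the compounds shown here, two have been measured so far in a functional assay on DU-145 cells (Homo sapiens) for inhibition, read by trypan blue exclusion, with a stated time of 96 h; a lower number here means a stronger inhibitor of growth, a higher number a weaker inhibitor of growth. Compound 1 `O=C(O)c1ccc(C(=O)/C(=C\c2ccc(Cl)c([N+](=O)[O-])c2)SCc2ccc(Cl)cc2)cc1` gives 1000 nM, and compound 2 `CN(C)c1ccc(/C=C(/SCc2ccc(Br)cc2)C(=O)c2ccc(C(=O)O)cc2)cc1` gives 50000 nM. Compound 2 therefore has the higher number of the two, which marks it as the weaker inhibitor of growth, and its gap to compound 1 lies well beyond the scatter of repeated measurements.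

The next compound to consider, compound 3 `O=C(O)c1ccc(C(=O)/C(=C\c2ccc(Cl)c([N+](=O)[O-])c2)SCc2ccc(Br)cc2)cc1`, has not yet been measured. Compared with compound 2, it has 4-chloro-3-nitrophenyl in place of 4-(dimethylamino)phenyl on a double-bonded chain carbon bound to a double-bonded chain carbon. Going by the values given here, no measured pair shows this change on its own, so its effect cannot be read directly from the data. Compound 1 also carries 4-chloro-3-nitrophenyl and stands at 1000 nM, so a large step toward a lower number, beyond the scatter, is expected in this assay. The estimated change a 50-fold lower number from compound 2 to compound 3 (1.70 log units; beyond the scatter) would be a clear gain in growth inhibition. For compound 3 the expected value is 1000 nM, with an estimated range of 300 nM to 3500 nM.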

Compound 3, concentration for 50% growth inhibition: 500 nM
Compound 3: middle estimate off by 2.0-fold (0.30 log units), on the high side; low and high end bracket the measured number.
By their numbers in this assay, from the lowest: compounds 3 and 1 (each within the scatter of the next); then compound 2.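

Replacing 4-(dimethylamino)phenyl with 4-chloro-3-nitrophenyl on a double-bonded chain carbon bound to a double-bonded chain carbon gives a 100-fold lower number from compound 2 to compound 3 (2.00 log units; beyond the scatter) in this assay. Compound 2 and compound 3 differ in this one place, so this pair isolates the effect of the swap, which the earlier pair could not do because compound 1 and compound 2 also differ in their halogen. Bromo in place of chloro on an aromatic carbon gives a 2.0-fold lower number from compound 1 to compound 3 (0.30 log units; within the scatter), so this halogen change cannot be told apart from ordinary assay variation, and no measurement at hand explains the large effect of the aryl swap.

As far as these compounds go, the entering group carries both a chloro and a nitro group, so it remains open whether either alone would produce the step, and how a plain phenyl or a methoxyphenyl would stand at this place. All three compounds also share a carboxylic acid, which leaves open what an ester or an amide in its place would do to growth inhibition.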